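Swapping Dimethylamino for Acetyl on a Shared Core

The source may hold more compounds than are shown below. What is called first, only, known or untested is meant among the compounds shown, and "the series" means these compounds.

Of the compounds shown here, two built on the same core have been measured so far. Compound 1 `COc1cc(C)cc(-c2c(-c3ccnc(-c4ccc(N(C)C)cc4)c3)cnn2CC#N)c1` and compound 2 `COc1cc(C)cc(-c2nn(CC#N)cc2-c2ccnc(-c3ccc(N(C)C)cc3)c2)c1` differ in how their groups are arranged around that core. In a functional assay on MOLT-4 cells (Homo sapiens) for cytotoxicity, read by sulforhodamine B assay, with a stated time of 48 h, tested at 0.01 uM (on this read-out higher numbers stand for a weaker effect at the one concentration tested and lower numbers for a stronger effect), compound 1 gives 81%, and compound 2 gives 93%. Going by the values given here, of these two numbers, the one for compound 1 is the lower, and the gap to compound 2 is wider than the usual scatter, so at this single concentration compound 1 shows the stronger effect of the pair.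

Among the compounds with values here, compound 3 `COc1cc(C)cc(-c2c(-c3ccnc(-c4ccc(C(C)=O)cc4)c3)cnn2CC#N)c1` keeps the arrangement of compound 1 and changes only one group: acetyl in place of dimethylamino on an aromatic carbon. Within the data shown here, no measured pair in this set carries such a change, so nothing measured here speaks to its size. Both measured values sit high, meaning a weak effect at this low concentration, and the swap leaves the rest of the molecule untouched. The step of a number 4 percentage points higher from compound 1 to compound 3 (within the scatter) is therefore expected to stay within the usual scatter, with no firm direction. Compound 3 is estimated at 85%, with a range from 65% to 100%.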

Compound 3, a percentage reported as activity, at one concentration (the size of the read-out at that concentration, not a potency): 99%
Compound 3: middle estimate off by 14 percentage points, on the low side, within the range that was stated.
By their numbers in this assay, from the lowest: compound 1; then compounds 2 and 3 (each within the scatter of the next).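

Until now, nothing measured touched this position on the aromatic ring, and the swap from 4-(dimethylamino)phenyl to 4-acetylphenyl gives a number 18 percentage points higher from compound 1 to compound 3 (beyond the scatter) in this assay. So the group at this place does matter at this single low concentration, and the higher number means that acetyl gives the weaker effect of this pair. The two groups match in heavy-atom count and in their counts of hydrogen-bond donors and acceptors, so those counts do not separate them, and no measurement here explains the step.

One swap at one concentration cannot show whether the effect follows a trend across groups at this position, such as a methoxy group, a primary amine or a carboxylic acid. The compounds shown also leave open whether acetyl would change the number in the same way on the arrangement of compound 2, and how the step would look as a true potency measured across several concentrations.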